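A few compounds are considered here, and "the series" means these few. Any claim that something is new, unique, unknown or untested is made for them only; others in the source may bear on it.

Of the compounds shown here, three share one core and have been measured in a physicochemical assay for lipophilicity, in phosphate buffer, measured as octanol-water partition, with a stated time of 24 h; a lower number here means a more polar compound, a higher number a more lipophilic compound. Compound 1 `O=C(CSc1nc2ccccc2s1)N/N=C/c1ccc(Oc2ccc(Cl)cc2)cc1` gives 5.6 in this assay. Compound 2 `Brc1ccc(Oc2ccc(/C=N/Nc3nc4ccccc4s3)cc2)cc1` gives 5.5 in this assay, and compound 3 `C(=N/Nc1nc2ccccc2s1)\c1ccc(Oc2ccc3ccccc3c2)cc1` gives 5.6 in this assay. Compound 2 therefore sits inside the usual scatter of both of the other two: its number differs from that of compound 1 by an amount that repeated measurements would not resolve, and the same holds against compound 3, so these three values cannot be told apart.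

Compound 4 `C(=N/Nc1nc2ccccc2s1)\c1ccc(Oc2ccccc2)cc1` has not yet been measured. It differs from compound 2 in a single place: hydrogen in place of bromo on an aromatic carbon. Within the data shown here, no pair of measured compounds shows this particular change, so there is no measured step to lean on. The expectation for this assay is that the step from compound 2 to compound 4 is a moderate fall, somewhat beyond the scatter, estimated as a number 0.70 log units lower from compound 2 to compound 4 (beyond the scatter). The value estimated for compound 4 in this assay is 4.8, with a range from 4.3 to 5.3.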

Compound 4, partition coefficient: 5.2
Estimate against measurement, compound 4: 0.40 log units below; measured number inside the range.
By their numbers in this assay, from the lowest: compounds 4, 2, 1 and 3 (each within the scatter of the next, the first and the last beyond it).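

In this assay, among these compounds, the replacement of bromo by hydrogen on an aromatic carbon, para to a large group, gives the first step in this set that changes one place only: a number 0.30 log units lower from compound 2 to compound 4 (within the scatter). Until now, the three measured compounds offered no direct view of what this position does, since no two of them differed in a single place; this pair shows that, with bromo or with hydrogen at this position, the numbers cannot be told apart by repeated measurement, so this one exchange is not resolved in this assay. No measurement at hand speaks to what lies behind the size of this step.

The compounds shown cover only bromo and hydrogen at this position on this core, so they leave open how the number would respond to an amine, a carboxylic acid or a longer chain such as a butoxy group on the same aromatic carbon. They also leave open whether the same exchange would give a similar step at another position of the outer ring or on a different core.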